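The compounds below may be only part of what the source reports. "The series", "measured", "known", "first", "only" and "open" are said of these compounds alone.

In a functional assay, read by spectrophotometry, with a stated time of 5 min (on this read-out higher numbers stand for weaker inhibition and lower numbers for stronger inhibition), compound 1, `O=c1cc(/C=N\c2ccc(O)cc2)c2ccc(OCc3ccccc3)cc2o1`, gives 525000 nM, and compound 2, `O=c1cc(/C=N\Nc2ccccc2)c2ccc(OCc3ccccc3)cc2o1`, gives 416000 nM. The step of a 1.3-fold lower number from compound 1 to compound 2 (0.10 log units; within the scatter) means compound 2 holds the lower of the two numbers, yet the gap to compound 1 is within the scatter, so neither can be called stronger. Compound 3, `O=c1cc(/C=N\O)c2ccc(OCc3ccccc3)cc2o1`, differs from compound 2 by hydroxy in place of anilino on a double-bonded nitrogen. For the measured compounds named here, the only measured step, a 1.3-fold lower number from compound 1 to compound 2 (0.10 log units; within the scatter), changed the group on this same nitrogen and left the number essentially unchanged; the new group is much smaller, so it is expected that the step of a 1.1-fold higher number from compound 2 to compound 3 (0.03 log units; within the scatter) again stays within the scatter. Compound 3 is therefore expected to give 450000 nM, with a range from 150000 nM to 1300000 nM.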

Compound 3, half-maximal inhibitory concentration: > 2000000 nM
Compound 3 ended at the assay's limit; the forecaster's own chance of this, stated with the estimate: 20%; middle value at least 4.4-fold (0.64 log units) away from the limit.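

Placing hydroxy on the double-bonded nitrogen gives an at least 4.8-fold higher number from compound 2 to compound 3 (0.68 log units; beyond the scatter), and an at least 3.8-fold higher number from compound 1 to compound 3 (0.58 log units; beyond the scatter), so this position can shift the number beyond the scatter, which a 1.3-fold lower number from compound 1 to compound 2 (0.10 log units; within the scatter) did not show. In this assay compound 3 gives > 2000000 nM, which is a limit of the assay and not a number. Both steps therefore give only a minimum size, and only compound 3 lacks a six-membered aromatic ring on this nitrogen.

From the compounds shown here alone, it remains open whether that ring itself matters or whether another group would serve as well. A methoxy or cyclohexylamino group at this place would help separate these possibilities.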